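Adding a methoxy group to compound 2

This account rests on a few compounds, and the source may have more. Where it says the series, first, only, none or still open, it means among the compounds named here.

Compound 1 `Cc1ccc(OCc2ccccc2)c(C/C=C/c2ccccc2/C=C/C(=O)NS(=O)(=O)c2cccs2)c1`: 2100 nM
Compound 2 `O=C(/C=C/c1ccccc1/C=C/Cc1ccccc1)NS(=O)(=O)c1cccs1`: 8000 nM

In an assay on isolated protein for binding affinity to prostaglandin E2 receptor EP2 subtype (Homo sapiens) (a higher number here means a weaker inhibitor, a lower number a stronger inhibitor), compound 2 gives the higher of the two numbers, and compound 1 gives a lower one, a gap beyond the usual scatter. Compound 3 `COc1ccc(C/C=C/c2ccccc2/C=C/C(=O)NS(=O)(=O)c2cccs2)cc1` is compound 2 with methoxy in place of hydrogen on an aromatic carbon. Among the compounds with values here, no measured pair shows this change on its own; compound 1 is the only guide, and it carries more substituents than compound 2 while binding more tightly. The step from compound 2 to compound 3 is therefore expected to be small and downward, a 1.8-fold lower number from compound 2 to compound 3 (0.25 log units; within the scatter), roughly within the scatter. Compound 3 is estimated at 4500 nM, with a likely range from 1500 nM to 12000 nM.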

Compound 3, inhibition constant: 6500 nM
Beside the measured number, compound 3's estimate is 1.4-fold (0.16 log units) below it, and the stated range covers the measured number.
By their numbers in this assay, from the lowest: compound 1; then compounds 3 and 2 (each within the scatter of the next).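

In this assay, putting methoxy in place of hydrogen on an aromatic carbon, para to a large group, gives a 1.2-fold lower number from compound 2 to compound 3 (0.09 log units; within the scatter) and so does not separate the two compounds. Within the data shown here, at this position, on this evidence, a phenyl and a 4-methoxyphenyl cannot be told apart, which no earlier single-change pair could show. No measurement given here bears on the reason for this result. From the compounds shown here alone, whether an amine, a carboxylic acid or a longer chain at the same position would give a number clearly different from that of compound 2 remains open. So does the effect of methoxy on the other carbons of this ring.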